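Extending vinyl to but-1-en-1-yl on a fluorinated core

A few compounds are considered here, and "the series" means these few. Any claim that something is new, unique, unknown or untested is made for them only; others in the source may bear on it.

Measured so far in a functional assay on A549 cells (Homo sapiens) for antiproliferative activity, read by MTT assay, with a stated time of 72 h; on this read-out lower numbers stand for stronger inhibition and higher numbers for weaker inhibition:
compound 1 `CC/C=C\C(=O)Nc1cc(Nc2nccc(-c3cn(C)c4ccccc34)n2)c(OC)cc1N(C)CCN(C)C` gives 1530 nM
compound 2 `C=CC(=O)Nc1cc(Nc2nccc(-c3cn(C)c4ccc(F)cc34)n2)c(OC)cc1N(C)CCN(C)C` gives 329 nM

Compound 2 holds the lower of the two numbers; compound 1 stands higher, beyond the scatter. These two differ in two places at once, so their values show only a combined effect. Compound 3 `CC/C=C\C(=O)Nc1cc(Nc2nccc(-c3cn(C)c4ccc(F)cc34)n2)c(OC)cc1N(C)CCN(C)C` keeps the fluorine of compound 2 and changes one spot: but-1-en-1-yl in place of vinyl on a carbonyl carbon. No single-change comparison for this swap exists here. Since compound 1 carries the same but-1-en-1-yl and gives 1530 nM, a move toward weaker inhibition is expected, estimated as a 2.7-fold higher number from compound 2 to compound 3 (0.44 log units; beyond the scatter). Compound 3 is therefore expected near 900 nM, within 300 nM to 2500 nM.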

Compound 3, half-maximal inhibitory concentration: 3600 nM
Estimate against measurement, compound 3: 4.0-fold (0.60 log units) below; the measured number lies above the stated range.
By their numbers in this assay, from the lowest: compound 2; then compound 1; then compound 3.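

In this assay, for the compounds shown here, the swap of vinyl for but-1-en-1-yl on a carbonyl carbon gives an 11-fold higher number from compound 2 to compound 3 (1.04 log units; beyond the scatter) and is the first single-change view of this position, showing that the longer chain costs much activity. With but-1-en-1-yl kept, fluoro in place of hydrogen on an aromatic carbon gives a 2.4-fold higher number from compound 1 to compound 3 (0.37 log units; beyond the scatter) as a modest loss rather than a gain. Nothing here explains either step. As far as these compounds go, how fluoro acts when vinyl sits on the carbonyl carbon stays open. So does the outcome with prop-1-en-1-yl or an amine-bearing chain there.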